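Propyl in place of hydroxy on the shared core

The source may hold more compounds than are shown below. What is called first, only, known or untested is meant among the compounds shown, and "the series" means these compounds.

Going by the values given here, compound 1 `Nc1nc(O)nc2c1nc(O)n2Cc1ccccc1` gives 1 mg/kg in a functional assay on the whole organism for activation, with Mus musculus as the target; on this read-out lower numbers stand for an effect already at smaller amounts and higher numbers for an effect only at larger amounts of compound; of the two numbers measured so far it stands highest, and its nearest neighbour is compound 2 `CCCCCOc1nc(N)c2nc(O)n(Cc3ccccc3)c2n1`, which gives 0.3 mg/kg. Among the compounds with values here, the one measured step, a 3.3-fold lower number from compound 1 to compound 2 (0.52 log units; beyond the scatter), puts pentyl in place of hydrogen on an oxygen on an aromatic ring of the shared core.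

Compound 3 `CCCc1nc(N)c2nc(O)n(Cc3ccccc3)c2n1` has not been measured. It differs from compound 1 by propyl in place of hydroxy on an aromatic carbon. This change removes the oxygen rather than extending it, so the step from compound 1 to compound 2 bears on it only indirectly: it shows that a longer chain at this position on the core went with a lower number. On that basis a modest lowering is expected for compound 3, a 2.0-fold lower number from compound 1 to compound 3 (0.30 log units; within the scatter), with wide uncertainty. The estimate for compound 3 in this assay is 0.5 mg/kg, within 0.15 mg/kg to 1.5 mg/kg.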

Compound 3, minimum effective dose: 3 mg/kg
Compound 3: middle estimate off by 6.0-fold (0.78 log units), on the low side, and the stated range ends below it.
By their numbers in this assay, from the lowest: compound 2; then compound 1; then compound 3.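

In this assay, replacing hydroxy with propyl on this aromatic carbon moves the number in the opposite direction from the pentyl step on the oxygen (a 3.0-fold higher number from compound 1 to compound 3 (0.48 log units; beyond the scatter)). A chain at this position therefore does not lower the number in itself. Replacing pentyloxy with propyl gives the largest step among the three compounds (a 10-fold higher number from compound 2 to compound 3 (1.00 log units; beyond the scatter)), and both compounds with oxygen on this carbon have lower numbers than the propyl compound, with no exception among the three.

That largest step changes chain length and the oxygen link together, so their contributions cannot be separated here; propoxy and pentyl on the same aromatic carbon would each change only one of them. No measured evidence is available on what lies behind these steps.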